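Chloro for methyl on the fused aromatic ring

The source may hold more compounds than are shown below. What is called first, only, known or untested is meant among the compounds shown, and "the series" means these compounds.

Compound 1 `COC(=O)[C@@]1(C)CCC=C2[C@@H]1CC[C@@H](C)[C@]2(C)Cc1c[nH]c2ccc(Br)cc12` carries bromo on the fused aromatic part of the shared core, and in a functional assay on SW1573 cells (Homo sapiens) for inhibition, read by sulforhodamine B assay, with a stated time of 48 h (a higher number here means a weaker inhibitor of growth, a lower number a stronger inhibitor of growth), compound 1 gives 12000 nM. Compound 2 `COC(=O)[C@@]1(C)CCC=C2[C@@H]1CC[C@@H](C)[C@]2(C)Cc1c[nH]c2c(C)cccc12` carries methyl instead, and in this assay compound 2 gives 7800 nM, the lower of the two numbers shown, although the gap to compound 1 lies within the scatter, so no order between the two can be read from it. Compound 3 `COC(=O)[C@@]1(C)CCC=C2[C@@H]1CC[C@@H](C)[C@]2(C)Cc1c[nH]c2c(Cl)cccc12` is the next case: chloro in place of methyl on an aromatic carbon. Among the measured compounds shown here, no measured pair shows this exact change; the only comparison available, compound 1 against compound 2, has bromo and methyl giving values within the scatter of one another. In this assay the step expected is a 1.0-fold lower number from compound 2 to compound 3 (0.02 log units; within the scatter), none beyond the scatter in either direction. Compound 3 is therefore estimated at 7500 nM, with a range from 3000 nM to 18000 nM.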

Compound 3, concentration for 50% growth inhibition: 14000 nM
Compound 3: middle estimate off by 1.9-fold (0.27 log units), on the low side, and the stated range covers the measured number.
By their numbers in this assay, from the lowest: compounds 2, 1 and 3 (each within the scatter of the next).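

In this assay, among the compounds shown here, the first direct pair at this position, chloro in place of methyl on an aromatic carbon, shows a 1.8-fold higher number from compound 2 to compound 3 (0.25 log units; within the scatter) and so sets no order between the two groups here. For the compounds shown here, the pair says only that this one exchange stays inside the scatter; it does not say that the position accepts any group equally. Nothing in hand bears on a cause for the result.

As far as these compounds go, whether a different kind of group on this same carbon, such as an amine, a hydroxyl or a carboxylic acid, would shift the number beyond the scatter remains open. Also open, from the compounds shown here alone, is whether a longer chain such as ethyl, or plain hydrogen at this carbon, would separate from methyl and chloro in this assay at all.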